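Ring-size change on the amide of a bicyclic diamine

The compounds below may be only part of what the source reports. "The series", "measured", "known", "first", "only" and "open" are said of these compounds alone.

Measured compounds:
compound 1 `O=C(C1CCC1)N1CC2CC(C1)N2`, 370 nM
compound 2 `O=C(C1CCCC1)N1CC2CC(C1)N2`, 1600 nM
compound 3 `O=C(CC1C=CCC1)N1CC2CC(C1)N2`, 21000 nM

In an assay on CHO cells for agonist activity at Neuronal acetylcholine receptor; alpha3/alpha6/beta2/beta3 (Homo sapiens), read by FLIPR and calcium flux (a higher number here means that more compound is needed for the effect, a lower number that less compound is needed), compound 1 gives the lowest of the three numbers; compound 2 sits beyond the scatter above it, and compound 3 lies further still. Compound 4 `C[C@@H]1C[C@@H]1C(=O)N1CC2CC(C1)N2` has not been measured in this assay. It differs from compound 1 by a group of 4 heavy atoms (4 carbon; one three-membered non-aromatic ring of carbon only) in place of a group of 4 heavy atoms (4 carbon; one four-membered non-aromatic ring of carbon only), on a carbonyl carbon. For the measured compounds named here, no measured pair shows this step, so its size is uncertain. Because compound 1 gives 370 nM with the smaller ring, while compound 2 gives 1600 nM, a group of the same atom count is expected to change the number little, within or only just beyond the scatter, as a 1.4-fold higher number from compound 1 to compound 4 (0.13 log units; within the scatter). Compound 4 is thus estimated at 500 nM, with a range from 150 nM to 2000 nM.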

Compound 4, half-maximal effective concentration: 920 nM
Beside the measured number, compound 4's estimate is 1.8-fold (0.26 log units) below it; measured number inside the range.
By their numbers in this assay, from the lowest: compound 1; then compounds 4 and 2 (each within the scatter of the next); then compound 3.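

In this assay, replacing the cyclobutyl on the carbonyl carbon with a three-membered carbon ring bearing 2 defined stereocentres, from the same atoms joined differently, gives a 2.5-fold higher number from compound 1 to compound 4 (0.40 log units; beyond the scatter) and so the number at this position depends on how those carbons are arranged, not only on how many there are. The step is modest but lies beyond the scatter. Nothing measured here offers an explanation for it. The compounds shown leave open how the other stereoisomers of the three-membered ring would read, and what an amine or a hydroxyl on the cyclobutyl would do.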